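Benzyl variation in the series: estimating compound 4

A few compounds are considered here, and "the series" means these few. Any claim that something is new, unique, unknown or untested is made for them only; others in the source may bear on it.

Three analogues sharing one core have been run in a functional assay on HepG2 cells (Homo sapiens) for antiproliferative activity, read by MTT assay, with a stated time of 24 h; on this read-out lower numbers stand for stronger inhibition and higher numbers for weaker inhibition. Compound 1 `O=[N+]([O-])c1ccccc1CSc1nnc(-c2ccc3c(c2)OCCO3)n1-c1ccccc1` gives 12000 nM, compound 2 `O=[N+]([O-])c1cccc(CSc2nnc(-c3ccc4c(c3)OCCO4)n2-c2ccccc2)c1` gives 49300 nM, and compound 3 `Clc1cccc(CSc2nnc(-c3ccc4c(c3)OCCO4)n2-c2ccccc2)c1` gives 2390 nM, the lowest of the three numbers. The measured steps are a 4.1-fold higher number from compound 1 to compound 2 (0.61 log units; beyond the scatter) and a 21-fold lower number from compound 2 to compound 3 (1.31 log units; beyond the scatter), together with a 5.0-fold lower number from compound 1 to compound 3 (0.70 log units; beyond the scatter). Compound 4 `Cc1ccc(CSc2nnc(-c3ccc4c(c3)OCCO4)n2-c2ccccc2)cc1` carries the change (4-methylphenyl in place of 3-chlorophenyl on a saturated chain carbon bound to a sulfur). Among the measured compounds shown here, no measured step puts a methyl on this ring, so size and direction of the step rest on little evidence. A modestly higher number is expected in this assay because compound 3 already gives 2390 nM as the lowest value seen, so a 1.9-fold higher number from compound 3 to compound 4 (0.27 log units; within the scatter) is expected. Compound 4 is estimated at 4500 nM, within 1500 nM to 14000 nM.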

Compound 4, half-maximal inhibitory concentration: 56800 nM
The estimate for compound 4 lay 13-fold (1.10 log units) below the measured number, and the stated range ends below it.
By their numbers in this assay, from the lowest: compound 3; then compound 1; then compounds 2 and 4 (each within the scatter of the next).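

Among the compounds shown here, only 3-chlorophenyl has given a low number at this position so far: 4-methylphenyl in its place gives a 24-fold higher number from compound 3 to compound 4 (1.38 log units; beyond the scatter) and erases the advantage of compound 3. The other comparisons give a 1.2-fold higher number from compound 2 to compound 4 (0.06 log units; within the scatter) and a 4.7-fold higher number from compound 1 to compound 4 (0.68 log units; beyond the scatter), so a non-nitro benzyl group does not by itself give a low number, and compound 3 stands alone at the low end of the four. No supporting measurement bears on this result.

3-Chlorophenyl and 4-methylphenyl differ in both substituent and ring position, and the split between these two changes stays open. As far as these compounds go, how an amine or a carboxylic acid on this ring would read also stays open.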